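Swapping Chloro for Dimethylamino on the Shared Core

This account rests on a few compounds, and the source may have more. Where it says the series, first, only, none or still open, it means among the compounds named here.

Three compounds share a core with a hydroxamic acid chain. Compound 1 `O=C(CCCCCCc1nc2ccccc2[nH]1)NO` gives 2700 nM in a functional assay on SK-OV-3 cells (Homo sapiens) for cytotoxicity; on this read-out higher numbers stand for weaker inhibition and lower numbers for stronger inhibition. Compound 2 `O=C(CCCCCCc1nc2ccc(Cl)cc2[nH]1)NO` gives 320 nM, the lowest of the three numbers, and compound 3 `CN(C)c1ccc(-c2ccc3nc(CCCCCCC(=O)NO)[nH]c3c2)cc1` gives 6600 nM. Compound 4 `CN(C)c1ccc2nc(CCCCCCC(=O)NO)[nH]c2c1` differs from compound 2 by dimethylamino in place of chloro on an aromatic carbon. Within the data shown here, two measured steps bear on this: an 8.4-fold lower number from compound 1 to compound 2 (0.93 log units; beyond the scatter), and a 21-fold higher number from compound 2 to compound 3 (1.31 log units; beyond the scatter). Both suggest that losing chloro costs potency, though dimethylamino is a smaller group than 4-(dimethylamino)phenyl, so a more modest rise in the number is expected. The step of a 6.3-fold higher number from compound 2 to compound 4 (0.80 log units; beyond the scatter) is the estimated result. Compound 4 is therefore expected to give about 2000 nM, within a range from 600 nM to 7000 nM.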

Compound 4, half-maximal inhibitory concentration: 1200 nM
The estimate for compound 4 lay 1.7-fold (0.22 log units) above the measured number, and the stated range covers the measured number.
By their numbers in this assay, from the lowest: compound 2; then compound 4; then compound 1; then compound 3.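

Putting dimethylamino in place of hydrogen at this position still lowers the number, with a 2.3-fold lower number from compound 1 to compound 4 (0.35 log units; beyond the scatter) in this series, but chloro remains the better group, with a 3.8-fold higher number from compound 2 to compound 4 (0.57 log units; beyond the scatter) on swapping it out. Dimethylamino alone also does not raise the number to the level of compound 3, with a 5.5-fold lower number from compound 3 to compound 4 (0.74 log units; beyond the scatter) on removing the phenyl part of the larger group. No measurement shown here explains why these groups rank as they do.

From the compounds shown here alone, it remains open where a fluoro, methoxy or plain amino group would fall at this position. A longer chain on the hydroxamic acid might also change this order.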